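This account rests on a few compounds, and the source may have more. Where it says the series, first, only, none or still open, it means among the compounds named here.

Measured in a functional assay on HL-60 cells (Homo sapiens) for cytotoxicity, read by WST assay, with a stated time of 48 h; a higher number here means a weaker inhibitor, a lower number a stronger inhibitor:
- Compound 1 `O[C@@H](c1ccccc1)[C@H]1CO[C@H](c2ccccc2)[C@@H](C/C=C/C2CCCC2)C1`: 9060 nM
- Compound 2 `COc1ccccc1/C=C/C[C@H]1C[C@@H]([C@@H](O)c2ccccc2)CO[C@@H]1c1ccccc1`: 10100 nM

Compound 2, at 10100 nM, holds the higher of these two numbers, but its gap to compound 1 lies within the scatter, so the two cannot be ranked in this assay. The next compound to be tested is compound 3 `O=[N+]([O-])c1ccc(/C=C/C[C@H]2C[C@@H]([C@@H](O)c3ccccc3)CO[C@@H]2c2ccccc2)cc1`. It differs from compound 2 in one place, on a double-bonded chain carbon bound to a double-bonded chain carbon: 4-nitrophenyl in place of 2-methoxyphenyl on a double-bonded chain carbon bound to a double-bonded chain carbon.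

Among the compounds with values here, only one measured step bears on this change. At the same place, 2-methoxyphenyl in place of cyclopentyl gave a 1.1-fold higher number from compound 1 to compound 2 (0.05 log units; within the scatter). That single small step gives no direction, so no shift beyond the scatter is expected. However, neither measured compound carries 4-nitrophenyl, and one step is thin evidence, so the range is kept wide. The expected change is a 1.1-fold lower number from compound 2 to compound 3 (0.05 log units; within the scatter). For compound 3 the estimate is 9000 nM, with an expected range from 3500 nM to 23000 nM.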

Compound 3, half-maximal inhibitory concentration: 4880 nM
Compound 3: the middle estimate sits 1.8-fold (0.27 log units) above what was measured; low and high end bracket the measured number.
By their numbers in this assay, from the lowest: compounds 3, 1 and 2 (each within the scatter of the next, the first and the last beyond it).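

In this assay, within the data shown here, this place on the chain shows a step beyond the scatter for the first time, with a 2.1-fold lower number from compound 2 to compound 3 (0.32 log units; beyond the scatter) as a modest change, whereas the earlier exchange of cyclopentyl for 2-methoxyphenyl could not be told from scatter. Set against cyclopentyl, the 4-nitrophenyl does not clear the scatter, with a 1.9-fold lower number from compound 1 to compound 3 (0.27 log units; within the scatter) and so no ranking of that pair, which means the group is separated from only one of the two groups it has been compared with. Nothing in the available data explains the difference between 4-nitrophenyl and 2-methoxyphenyl.

The compounds shown include no unsubstituted phenyl, 4-methoxyphenyl or 2-nitrophenyl at this place, so it remains open whether the step follows from the nitro group, from the loss of the methoxy group, or from where each sits on the ring. From the compounds shown here alone, it is equally open whether a phenyl carrying an amine or a carboxylic acid would extend the step or leave the number within the scatter of these three compounds.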